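Replacing the aryl group on the ring nitrogen

This account rests on a few compounds, and the source may have more. Where it says the series, first, only, none or still open, it means among the compounds named here.

In an ADME assay on HEp-2 cells (Homo sapiens) for cytotoxicity, read by CCK-8 assay, with a stated time of 6 days (a lower number here means that less compound is tolerated, a higher number that more compound is tolerated), the three measured compounds, which share one core, stand as follows.
Compound 1, `NCCNc1cc(N2CCN(C(=O)CCc3ccccc3)CC2)nc2ccccc12`, gives > 100000 nM, and that value is a limit of the assay rather than a number.
Compound 2, `NCCNc1cc(N2CCN(c3cccc(Cl)c3)CC2)nc2ccccc12`, gives 6400 nM.
Compound 3, `NCCNc1cc(N2CCN(C(=O)C3(c4ccccc4)CCCC3)CC2)nc2ccccc12`, gives > 100000 nM, which again is a limit of the assay.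

Among the compounds with values here, compound 2 therefore holds the only true number in this assay; the other two values sit at the limit of > 100000 nM in this assay, at which 2 of the 3 values shown sit. Compound 4, `CC(C)CC(=O)N1CCN(c2cc(NCCN)c3ccccc3n2)CC1`, differs from compound 2 in a single place: isobutylcarbonyl in place of 3-chlorophenyl on an amine nitrogen in a ring. Within the data shown here, one measured step bears directly on this change, an at least 15-fold lower number from compound 1 to compound 2 (1.19 log units; beyond the scatter), where a carbonyl-bearing group on the same ring nitrogen was exchanged for the 3-chlorophenyl. The move from compound 2 to compound 4 runs the other way, back to a carbonyl-bearing group, as carried by compound 1 and compound 3; the step between those two, a step that the two limits leave unreadable from compound 1 to compound 3, cannot be sized because both sit at the limit. A large rise in the number for compound 4 is therefore expected, with a good chance that only a limit is reported. The expected step is a 16-fold higher number from compound 2 to compound 4 (1.19 log units; beyond the scatter). Compound 4 is estimated at 100000 nM, within 30000 nM to 300000 nM.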

Compound 4, half-maximal cytotoxic concentration: > 100000 nM
Compound 4 gave a limit, no number; the forecaster's own chance of this, stated with the estimate: 65%; the middle value lies on the limit itself.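

In this assay, the change to isobutylcarbonyl gives an at least 15-fold higher number from compound 2 to compound 4 (1.19 log units; beyond the scatter). Within the data shown here, until now, the only readable step at this ring nitrogen involved a carbonyl-bearing group with an aromatic ring, whereas isobutylcarbonyl has no ring, so the large gap to the 3-chlorophenyl of compound 2 does not depend on that aromatic ring in the group. All three carbonyl-bearing groups, in compound 1, compound 3 and compound 4, now end at a limit rather than a number, so the steps among them cannot be read and the groups cannot be ranked: the limit of > 100000 nM in this assay, at which 3 of the 4 values shown sit.

The compounds shown leave open whether the higher number goes with the carbonyl itself or with the loss of the 3-chlorophenyl, a question that a plain isobutyl on the ring nitrogen or a 3-chlorobenzoyl group would help to separate. They also leave open what the chlorine contributes, which an unsubstituted phenyl on the same nitrogen would test against compound 2.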